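This account rests on a few compounds, and the source may have more. Where it says the series, first, only, none or still open, it means among the compounds named here.

Three compounds have values in a functional assay on Bel-7402 cells (Homo sapiens) for inhibition, read by sulforhodamine B assay, with a stated time of 72 h (a lower number here means a stronger inhibitor, a higher number a weaker inhibitor), so far.

Compound 1 `C[C@H](Nc1ncnc2[nH]cnc12)c1nn(-c2cccnc2)c2ccc(F)cc12` gives 31900 nM
Compound 2 `C[C@H](Nc1ncnc2[nH]cnc12)c1nn(-c2ccc(C#N)cc2)c2cc(F)ccc12` gives 31500 nM
Compound 3 `C[C@H](Nc1nc(N)nc(N)c1C#N)c1nn(-c2cccc(S(C)(=O)=O)c2)c2cc(Cl)ccc12` gives 4460 nM

Compound 2 lies within the scatter of compound 1, and its number stands above that of compound 3 by more than the scatter. Compound 4 `C[C@H](Nc1ncnc2[nH]cnc12)c1nn(-c2cc(F)cc(F)c2)c2cc(F)ccc12` is not yet measured and differs from compound 2 by 3,5-difluorophenyl in place of 4-cyanophenyl on an aromatic nitrogen. Compound 1 at 31900 nM and compound 2 at 31500 nM bear different groups on that nitrogen yet agree within the scatter, so no step beyond the scatter is expected in this assay here. The estimated change is a 1.3-fold lower number from compound 2 to compound 4 (0.10 log units; within the scatter) and would lie within the scatter. The expected value for compound 4 is 25000 nM with an estimated range from 10000 nM to 60000 nM.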

Compound 4, half-maximal inhibitory concentration: > 40000 nM
Compound 4: only a limit was reported; the forecaster's own chance of this, stated with the estimate: 15%; middle value at least 1.6-fold (0.20 log units) from the limit.
By their numbers in this assay, from the lowest: compound 3; then compounds 2 and 1 (each within the scatter of the next). At a limit, above all of these: compound 4.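

In this assay compound 4 gives > 40000 nM, which is a limit and not a number. With 3,5-difluorophenyl in place of 4-cyanophenyl on the aromatic nitrogen, the first readable step at this position is an at least 1.2-fold higher number from compound 2 to compound 4 (0.10 log units; that floor lies within the scatter), so this change gives no sign of a stronger inhibitor, though the step is only a floor: the limit of > 40000 nM in this assay, at which 1 of the 4 values shown sits.

On these data alone, how far compound 4 actually lies from compound 2 stays open. Also open, as far as these compounds go, is what a phenyl carrying an amine or a carboxylic acid on that nitrogen would give in this assay.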